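Ethyl for Chloro at the Outer Ring: Compound 4

A few compounds are considered here, and "the series" means these few. Any claim that something is new, unique, unknown or untested is made for them only; others in the source may bear on it.

Compound 1 `Cc1ccccc1Oc1cccc(COc2ccccc2CCC(=O)OCCCOP(=O)(O)OC[C@H](N)C(=O)O)c1` gives 20.3% in an assay on cells for agonist activity at probable G-protein coupled receptor 34 (Mus musculus), with a stated time of 1 h; a higher number here means a larger maximal response, a lower number a smaller maximal response. Compound 2 `Cc1ccc(Oc2cccc(COc3ccccc3CCC(=O)OCCCOP(=O)(O)OC[C@H](N)C(=O)O)c2)cc1` gives 18.2%. Compound 3 `N[C@@H](COP(=O)(O)OCCCOC(=O)CCc1ccccc1OCc1cccc(Oc2ccc(Cl)cc2)c1)C(=O)O` gives 17.8%.

These three compounds share one core and differ only in the small group at the outer end. In this assay compound 3 has the lowest of the three numbers, but its gaps to the others are small: a number 0.4 percentage points lower from compound 2 to compound 3 (within the scatter) and a number 2.5 percentage points lower from compound 1 to compound 3 (within the scatter), both within the scatter, so nothing separates the three beyond the noise of the assay.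

Compound 4 `CCc1ccc(Oc2cccc(COc3ccccc3CCC(=O)OCCCOP(=O)(O)OC[C@H](N)C(=O)O)c2)cc1` arises from compound 3 by one change: ethyl in place of chloro on an aromatic carbon. Within the data shown here, the step that bears most closely on this is the one between compound 2 and compound 3, where a chloro took the place of a methyl on the same aromatic carbon: a number 0.4 percentage points lower from compound 2 to compound 3 (within the scatter). The other two steps, a number 2.1 percentage points lower from compound 1 to compound 2 (within the scatter) and a number 2.5 percentage points lower from compound 1 to compound 3 (within the scatter), also stayed within the scatter. Swapping groups at this position has so far moved the maximal response by nothing beyond the usual variation, so no step beyond the scatter is expected in this assay here either.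

Compound 4 is therefore estimated to give 19%, with a range of 10% to 28%, an expected step of a number 1.2 percentage points higher from compound 3 to compound 4 (within the scatter).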

Compound 4, largest response reached (Emax), in percent of the reference or control that the assay uses: 19.3%
For compound 4 the middle estimate is 0.3 percentage points below the measured one; the measured number falls inside the stated range.
By their numbers in this assay, from the lowest: compounds 3, 2, 4 and 1 (each within the scatter of the next).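

In this assay, ethyl and chloro on this aromatic carbon cannot be told apart (a number 1.5 percentage points higher from compound 3 to compound 4 (within the scatter)), so a group of two carbon atoms can stand where a single chlorine atom stood without a step beyond the scatter. The earlier compounds shown here only swapped one single-atom group for another or shifted the methyl on the outer ring, whereas compound 4 also extends a group: one more carbon on the methyl of compound 2 (a number 1.1 percentage points higher from compound 2 to compound 4 (within the scatter)) leaves the maximal response within the scatter, and the comparison of the 2-methylphenyl of compound 1 with the 4-ethylphenyl ends the same way (a number 1 percentage points lower from compound 1 to compound 4 (within the scatter)). No other measurement bears on this result, so these close numbers remain a plain observation.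

All the groups shown at this place are small, so it remains open whether an amine, a carboxylic acid or a longer chain such as butyl would give a step beyond the scatter. From the compounds shown here alone, it is also open whether ethyl would read the same at the 2-position of the outer ring, where compound 1 carries its methyl.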